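The source may report more compounds than this note shows. Statements on the series, on what has been measured and on what is new or still open speak of the compounds shown alone.

Compound 1 `NC1=NC2(CCOCC2)N(OCCCOc2cccc(Cl)c2)C(N)=N1`: 150 nM
Compound 2 `NC1=NC2(CCOCC2)N(OCCCOc2cccc(Cl)c2Cl)C(N)=N1`: 330 nM

In a functional assay on HepG2 cells (Homo sapiens) for antiproliferative activity, read by MTT assay, with a stated time of 72 h (a lower number here means a stronger inhibitor, a higher number a weaker inhibitor), compound 2 stands at the highest of the two numbers; its nearest neighbour is compound 1, and the difference between them is a 2.2-fold higher number from compound 1 to compound 2 (0.34 log units; beyond the scatter). Compound 3 `NC1=NC2(CCOCC2)N(OCCCOc2ccccc2Cl)C(N)=N1` differs from compound 2 in one place: hydrogen in place of chloro on an aromatic carbon. The chloro that leaves sits on an aromatic carbon ortho to a chloro group and meta to a large group.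

Among the compounds with values here, only one measured step is available, a 2.2-fold higher number from compound 1 to compound 2 (0.34 log units; beyond the scatter), and it describes a chloro entering at a different carbon of the same ring, so it bears on the present change only indirectly. Both measured compounds lie close together, and a small step is therefore expected, a 1.3-fold lower number from compound 2 to compound 3 (0.12 log units; within the scatter), in either direction. On this basis compound 3 is estimated at 250 nM, with a range from 100 nM to 650 nM.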

Compound 3, half-maximal inhibitory concentration: 1750 nM
Estimate against measurement, compound 3: 7.0-fold (0.85 log units) below; measured number above the stated range.
By their numbers in this assay, from the lowest: compound 1; then compound 2; then compound 3.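

The chloro that leaves here turns out to carry more weight in this assay than the earlier pair suggested: taking it away gives a 5.3-fold higher number from compound 2 to compound 3 (0.72 log units; beyond the scatter), a larger step than the one seen when the second chloro entered, a 2.2-fold higher number from compound 1 to compound 2 (0.34 log units; beyond the scatter). Where the single chloro sits on the ring also matters, since 2-chlorophenyl in place of 3-chlorophenyl gives a 12-fold higher number from compound 1 to compound 3 (1.07 log units; beyond the scatter), which leaves compound 1, with only the 3-chlorophenyl group, as the strongest of the series and compound 3 as the weakest. Nothing measured here accounts for this difference between the two chloro positions.

The compounds shown leave open whether chloro is the only group that serves at this carbon, or whether fluoro, bromo, methyl or methoxy would do as well. They also leave open how a plain phenyl ring, with no chloro at all, would compare.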